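Amide-nitrogen variation: the step from compound 3 to compound 4

The source may report more compounds than this note shows. Statements on the series, on what has been measured and on what is new or still open speak of the compounds shown alone.

Three compounds of this series have numbers in a functional assay on PC-3 cells (Homo sapiens) for cytotoxicity, read by MTT assay, with a stated time of 48 h; on this read-out lower numbers stand for stronger inhibition and higher numbers for weaker inhibition. Compound 1 `CNC(=O)c1cc(Oc2cccc(NC(=S)Nc3ccc(Cl)cc3)c2)ccn1` gives 24100 nM in this assay. Among the measured compounds shown here, compound 2 `CC(C)NC(=O)c1cc(Oc2cccc(NC(=S)Nc3ccc(Cl)cc3)c2)ccn1` gives 21200 nM in this assay; the only single-point step measured, a 1.1-fold lower number from compound 1 to compound 2 (0.06 log units; within the scatter), lies within the scatter. Compound 3 `CCNC(=O)c1cc(Oc2cccc(NC(=S)Nc3ccc(F)c(F)c3)c2)ccn1` gives 26300 nM in this assay. Compound 3 holds the highest of the three numbers, but its gaps to compound 1 and to compound 2 are within the scatter, so the three stand together and no order among them is read.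

Compound 4 `O=C(c1cc(Oc2cccc(NC(=S)Nc3ccc(F)c(F)c3)c2)ccn1)N1CCCC1` differs from compound 3 by pyrrolidin-1-yl in place of ethylamino on a carbonyl carbon. For the measured compounds named here, the one measured step that bears on this place is a 1.1-fold lower number from compound 1 to compound 2 (0.06 log units; within the scatter), an exchange of the group on the amide-type nitrogen, and it produced no change beyond the scatter. Going by the values given here, the counted difference here also removes the single hydrogen-bond donor, for which no measured step exists; the halogen pattern is that of compound 3 and stays unchanged.

On this basis the expected step is a 1.1-fold lower number from compound 3 to compound 4 (0.02 log units; within the scatter), that is, none beyond the scatter, in this assay. Compound 4 is therefore estimated at 25000 nM, with a range from 10000 nM to 60000 nM.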

Compound 4, half-maximal inhibitory concentration: 45600 nM
The estimate for compound 4 lay 1.8-fold (0.26 log units) below the measured number; the range from low to high includes it.
By their numbers in this assay, from the lowest: compounds 2, 1, 3 and 4 (each within the scatter of the next, the first and the last beyond it).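

In this assay, pyrrolidin-1-yl in place of ethylamino on a carbonyl carbon gives a 1.7-fold higher number from compound 3 to compound 4 (0.24 log units; within the scatter) and so stays within the scatter, and this is the only measured step shown that removes the amide hydrogen and closes the amide nitrogen into a ring. Read with a 1.1-fold lower number from compound 1 to compound 2 (0.06 log units; within the scatter) as the other step at this place, it means that two different exchanges on the amide nitrogen have so far produced no change beyond the scatter, now including one that leaves no hydrogen-bond donor in the group. No measurement at hand offers an explanation for this result.

Loss of the amide hydrogen and formation of the ring arrive together in this step, so their separate contributions remain open, as does the reading of the same exchange with the chlorine-bearing aryl group of compound 1 in place of the halogen pattern of compound 3. Also open, as far as these compounds go, is whether a morpholine ring, a longer chain on the amide nitrogen or a carboxylic acid in place of the amide would give a step beyond the scatter.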